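The source may hold more compounds than are shown below. What is called first, only, known or untested is meant among the compounds shown, and "the series" means these compounds.

Compound 1 `CCCC(C)Oc1ccc(C(=O)/C=C/c2c(/C=C/c3ccc(OC)cc3)cc(OC)cc2OC)cc1` gives 6.7 ug/mL in a functional assay on B16-F10 cells (Mus musculus) for antiproliferative activity, read by MTT assay, with a stated time of 48 h; on this read-out lower numbers stand for stronger inhibition and higher numbers for weaker inhibition. Compound 2 `COc1ccc(/C=C/c2cc(OC)cc(OC)c2/C=C/C(=O)c2cccc(Cl)c2)cc1` gives 3.3 ug/mL in this assay.

On these two numbers compound 1 stands highest; its nearest neighbour is compound 2, reached by a 2.0-fold lower number from compound 1 to compound 2 (0.31 log units; beyond the scatter), a modest step that exchanges the 4-(1-methylbutoxy)phenyl on the carbonyl carbon for a 3-chlorophenyl. Compound 3 `COc1ccc(/C=C/c2cc(OC)cc(OC)c2/C=C/C(=O)c2ccc(Br)cc2)cc1` has not yet been measured. It differs from compound 1 by bromo in place of 1-methylbutoxy on an aromatic carbon. Among the measured compounds shown here, the one measured step that bears on this change is the one from compound 1 to compound 2, since there too the 1-methylbutoxy group on the carbonyl-bearing ring is lost and a halogen-substituted phenyl takes its place; that step lowered the number by a modest amount, beyond the scatter. For the measured compounds named here, on that basis a step of about the same size and in the same direction, towards a lower number, is expected for compound 3 in this assay, though with only one comparison the expectation is loosely held. Compound 3 is therefore estimated at 3.5 ug/mL, within a range of 1.7 ug/mL to 7.5 ug/mL, which corresponds to an expected step of a 1.9-fold lower number from compound 1 to compound 3 (0.28 log units; within the scatter).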

Compound 3, half-maximal inhibitory concentration: 6.5 ug/mL
Compound 3: middle estimate off by 1.9-fold (0.27 log units), on the low side; measured number inside the range.
By their numbers in this assay, from the lowest: compounds 2, 3 and 1 (each within the scatter of the next, the first and the last beyond it).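

In this assay, putting bromo in place of 1-methylbutoxy on this aromatic carbon gives a 1.0-fold lower number from compound 1 to compound 3 (0.01 log units; within the scatter), so losing the 1-methylbutoxy group for a halogen does not by itself carry the step seen earlier between compound 1 and compound 2. Going from the 3-chlorophenyl to the 4-bromophenyl on the carbonyl carbon gives a 2.0-fold higher number from compound 2 to compound 3 (0.29 log units; within the scatter), which leaves compound 3 within the scatter of both neighbours, even though those two lie beyond the scatter of each other; the three numbers therefore form a narrow band rather than a clear ranking of these aryl groups. Nothing at hand accounts for these numbers.

The step between compound 2 and compound 3 alters both the halogen and its place on the ring, so the compounds shown cannot separate the two changes, and a 4-chlorophenyl or 3-bromophenyl would be needed to do so. As far as these compounds go, it also remains open how an amine or a carboxylic acid on this same aromatic carbon would read in this assay, or a chain longer than 1-methylbutoxy.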